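Methoxy for Methyl on the Shared Core

The source may report more compounds than this note shows. Statements on the series, on what has been measured and on what is new or still open speak of the compounds shown alone.

Among the three compounds measured so far in a functional assay on A549 cells (Homo sapiens) for antiproliferative activity, read by MTT assay, with a stated time of 48 h (a lower number here means a stronger inhibitor, a higher number a weaker inhibitor), compound 3 `Cc1ccc(/C=C/C(=O)Nc2nnc(-c3ccccc3)s2)cc1` gives 1.58 ug/mL, the highest of the three numbers. Compound 1 `Cc1ccc(/C=C/C(=O)Nc2nnc(-c3ccc(Br)cc3)s2)cc1` gives 1.51 ug/mL, and the step of a 1.0-fold higher number from compound 1 to compound 3 (0.02 log units; within the scatter) lies within the scatter, so the two stand level. Compound 2 `COc1ccc(/C=C/C(=O)Nc2nnc(-c3ccc(C)cc3)s2)cc1` gives 0.66 ug/mL, which is beyond the scatter below the number of compound 3; compound 2 differs from compound 3 in two places, so no single step can be read from that pair.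

The next compound, compound 4 `COc1ccc(/C=C/C(=O)Nc2nnc(-c3ccccc3)s2)cc1`, differs from compound 3 in one place: methoxy in place of methyl on an aromatic carbon. Among the compounds with values here, no measured step covers this exchange. Within the data shown here, the only measured step, a 1.0-fold higher number from compound 1 to compound 3 (0.02 log units; within the scatter), concerns the other ring and was within the scatter, so it does not bear on the change. What compound 2 does show is that a methoxy on this ring goes together with a number beyond the scatter below that of compound 3, though that comparison is confounded by the second difference.

The step expected from this exchange is therefore a 1.6-fold lower number from compound 3 to compound 4 (0.20 log units; within the scatter), a modest lowering of the number, with a result inside the scatter of compound 3 also quite possible. Compound 4 is expected to give 1 ug/mL, with a range from 0.5 ug/mL to 2.2 ug/mL.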

Compound 4, half-maximal inhibitory concentration: 0.76 ug/mL
Estimate against measurement, compound 4: 1.3-fold (0.12 log units) above; measured number inside the range.
By their numbers in this assay, from the lowest: compounds 2, 4, 1 and 3 (each within the scatter of the next, the first and the last beyond it).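

Within the data shown here, on this ring, para to a large group, the change from 4-methylphenyl to 4-methoxyphenyl now has a step of its own in this assay (a 2.1-fold lower number from compound 3 to compound 4 (0.32 log units; beyond the scatter)), and it lies just beyond the scatter, which no earlier single-place step did. Among these compounds, the other ring shows no such step: hydrogen in place of methyl there stays within the scatter with methoxy on the first ring (a 1.2-fold higher number from compound 2 to compound 4 (0.06 log units; within the scatter)), as hydrogen in place of bromo did with methyl on the first ring (a 1.0-fold higher number from compound 1 to compound 3 (0.02 log units; within the scatter)), so across these four compounds only the exchange at the methyl position moves the number beyond the scatter. This rests on a single pair, and nothing given here accounts for the difference between methoxy and methyl at this position.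

Going by these compounds, it remains open whether an ethoxy, a hydroxy or an amine at this place would take the number further in the same direction, or whether hydrogen there would undo the step. Also open, on these data alone, is whether methoxy gives a similar step when a bromo sits on the other ring.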